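Swapping the aryl group on a weak cell-growth inhibitor

The source may report more compounds than this note shows. Statements on the series, on what has been measured and on what is new or still open speak of the compounds shown alone.

Of the compounds shown here, three built on one shared core have been tested in a functional assay on DU-145 cells (Homo sapiens) for inhibition, read by MTT assay, with a stated time of 24 h; a lower number here means a stronger inhibitor, a higher number a weaker inhibitor. Compound 1 `O=C(O)C1=Cc2ccccc2OC1(OCc1cc(-c2ccc(F)cc2)no1)C(F)(F)F` gives 168000 nM. Compound 3 `O=C(O)C1=Cc2ccccc2OC1(OCc1cc(-c2ccc(F)cc2F)no1)C(F)(F)F` differs from compound 1 by fluoro in place of hydrogen on an aromatic carbon, and in this assay compound 3 returns only a limit of the assay, > 150000 nM. The step that the limit leaves unreadable from compound 1 to compound 3 can therefore not be sized. Compound 2 `CCOC(=O)C1=Cc2ccccc2OC1(OCc1cn(CC(=O)Nc2ccc(C)cc2)nn1)C(F)(F)F` carries a different side chain on the same core, and in this assay compound 2 likewise returns only a limit, > 150000 nM. Compound 2 thus stands at the edge of what the assay can report, because of the limit of > 150000 nM in this assay, at which 2 of the 3 values shown sit.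

Compound 4 `CCOC(=O)C1=Cc2ccccc2OC1(OCc1cn(CC(=O)Nc2cccc(Cl)c2)nn1)C(F)(F)F` is the next compound to be measured. Its change from compound 2 is 3-chlorophenyl in place of 4-methylphenyl on an amide-type nitrogen. Within the data shown here, no measured step touches this position, and the one measured step concerns a different part of the molecule and is itself unreadable, so there is no basis for expecting a change beyond the scatter in either direction. Compound 4 is therefore expected to sit near the limit, at about 200000 nM, within 100000 nM to 400000 nM. The expected step that the limit leaves unreadable from compound 2 to compound 4 is only nominal, since compound 2 itself gives no number.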

Compound 4, half-maximal inhibitory concentration: 10100 nM
The estimate for compound 4 lay 20-fold (1.30 log units) above the measured number, and the stated range ends above it.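

In this assay, among these compounds, 3-chlorophenyl in place of 4-methylphenyl on an amide-type nitrogen gives an at least 14-fold lower number from compound 2 to compound 4 (1.17 log units; beyond the scatter), the first step in this set whose size can be read at all. The earlier compounds shown here gave no information about this position, and the result now shows that the aryl group on this amide can move the number well beyond the scatter. That happens even though both groups are one six-membered aromatic ring of carbon only, with the same counts of heavy atoms, hydrogen-bond donors and acceptors, and so the true step could be larger than the one printed, because compound 2 has no number of its own: the limit of > 150000 nM in this assay, at which 2 of the 4 values shown sit.

The compounds shown leave open whether the lower number comes from the chlorine arriving, from the methyl leaving, or from where the substituent sits on the ring. A 4-chlorophenyl or a 3-methylphenyl group on the same amide nitrogen would separate these possibilities, and nothing here tells why the change has this effect.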